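Halogen exchange on the benzylidene ring: cytotoxicity notes

The compounds below may be only part of what the source reports. "The series", "measured", "known", "first", "only" and "open" are said of these compounds alone.

Three hydrazones share one core. Compound 1 `O=C(N/N=C/c1ccccc1F)c1cnccn1` and compound 3 `O=C(N/N=C/c1ccccc1Br)c1cnccn1` carry a halogen ortho to a large group, while compound 2 `O=C(N/N=C/c1ccc(F)cc1)c1cnccn1` carries its fluoro para to a large group. In an ADME assay on J774 cells (Mus musculus) for cytotoxicity, read by MTT assay, with a stated time of 48 h, tested at 100 ug/mL (on this read-out higher numbers stand for a weaker effect at the one concentration tested and lower numbers for a stronger effect), compound 1 gives 100%, compound 3 gives 100% and compound 2 gives 69%. The change bromo in place of fluoro on an aromatic carbon produced no change at the digits printed from compound 1 to compound 3 (within the scatter). Compound 2 stands lowest of the three, beyond the scatter from both compound 1 and compound 3; the difference between the core of compound 2 and the core of compound 1 is not broken down here.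

Compound 4 `O=C(N/N=C/c1ccc(Br)cc1)c1cnccn1` is still to be measured in this assay. It relates to compound 2 through (bromo in place of fluoro on an aromatic carbon), the same kind of change as that from compound 1 to compound 3, though there the place was ortho to a large group and here it is para to a large group. From compound 2 to compound 4 a step of a number 5 percentage points higher from compound 2 to compound 4 (within the scatter) is expected, resting on no change at the digits printed from compound 1 to compound 3 (within the scatter), where the same change left the read-out unmoved. Compound 4 is therefore estimated at 74%, between 55% and 100%.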

Compound 4, a percentage reported as activity, at one concentration (the size of the read-out at that concentration, not a potency): 100%
Beside the measured number, compound 4's estimate is 26 percentage points below it, within the range that was stated.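

Bromo in place of fluoro on an aromatic carbon, here para to a large group, gives a number 31 percentage points higher from compound 2 to compound 4 (beyond the scatter) in this assay, which means a weaker effect at the one concentration tested. Among the compounds shown here, the change therefore does not carry over at one size between the two pairs: the same change on two cores in this assay, no change at the digits printed (within the scatter) from compound 1 to compound 3 and a number 31 percentage points higher (beyond the scatter) from compound 2 to compound 4, 31 percentage points apart, beyond the scatter of two such steps This shows that a step read on one pair cannot be transferred to the other, but with only two pairs it does not show whether the halogen's place or some other difference between the cores accounts for the gap, and it gives no rule for any further core.

The compounds shown leave open whether a chloro group, or a non-halogen group such as a methoxy group or an amine, in the same place would stay with the number of compound 2 or with that of compound 4. Also open, as far as these compounds go, is whether a carboxylic acid on this ring would move the read-out at all.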